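A Bromophenyl Sulfonamide Beside Three Cytotoxicity Limits

A few compounds are considered here, and "the series" means these few. Any claim that something is new, unique, unknown or untested is made for them only; others in the source may bear on it.

Compound 2 `CC1CCN(C2CCN(S(=O)(=O)c3ccc(C#N)cc3)CC2)CC1` is one of three compounds tested in an ADME assay on HCT-116 cells (Homo sapiens) for cytotoxicity, read by CellTiter-Glo, with a stated time of 72 h; on this read-out higher numbers stand for weaker inhibition and lower numbers for stronger inhibition. In this assay compound 2 reaches only the assay limit, > 5000 nM. Compound 1 `Cc1noc(C)c1S(=O)(=O)N1CCC(N2CCC(C)CC2)CC1` likewise gives only a limit in this assay, > 10000 nM. Compound 3 `CCCCOc1ccc(S(=O)(=O)N2CCC(N3CCC(C)CC3)CC2)cc1` also stops at a limit in this assay, > 5000 nM. The step that the two limits leave unreadable from compound 1 to compound 2 and the step that the two limits leave unreadable from compound 2 to compound 3 therefore have no readable size, as the limit of > 10000 nM in this assay, at which 1 of the 3 values shown sits, and the limit of > 5000 nM in this assay, at which 2 of the 3 values shown sit, record. Compound 4 `CC1CCN(C2CCN(S(=O)(=O)c3ccccc3Br)CC2)CC1` differs from compound 2 by 2-bromophenyl in place of 4-cyanophenyl on a sulfonyl sulfur. Neither measured step bears readably on this change, so no step beyond the scatter is expected in this assay, and another limit is the likeliest outcome. Compound 4 is therefore expected to give about 10000 nM, between 4000 nM and 30000 nM. The step this estimate means, a step that the limit leaves unreadable from compound 2 to compound 4, is expected to lie within the scatter.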

Compound 4, half-maximal inhibitory concentration: > 5000 nM
Compound 4: a limit, no number; the forecaster's own chance of this, stated with the estimate: 85%; the middle value does not contradict the limit.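

In this assay compound 4 stops at a limit, > 5000 nM, so its steps from compound 1 and compound 2 cannot be read. The compounds shown leave open whether any group on the sulfonyl sulfur changes the read-out.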